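The source may report more compounds than this note shows. Statements on the series, on what has been measured and on what is new or still open speak of the compounds shown alone.

Measured in a functional assay on MGC-803 cells (Homo sapiens) for cytotoxicity, read by MTT assay, with a stated time of 48 h; a lower number here means a stronger inhibitor, a higher number a weaker inhibitor:
Compound 1 `CC1=NN(C(=O)CN2CCN(C)CC2)C(c2ccccc2O)C1` gives 7850 nM.
Compound 2 `CC(=O)Oc1ccccc1C1CC(C)=NN1C(=O)CCl` gives 3010 nM.
Compound 3 `CNCC(=O)N1N=C(c2cc3ccccc3oc2=O)CC1c1ccccc1` gives 12800 nM.

Compound 3 carries the highest of the three numbers. Compound 1 stands nearest to it, within the scatter, so no order is read between compound 3 and compound 1; compound 2 lies further off, beyond the scatter, with the lower number. Compound 4 `CN1CCN(CC(=O)N2N=C(c3cc4ccccc4oc3=O)CC2c2ccccc2)CC1` differs from compound 3 in one place: 4-methylpiperazin-1-yl in place of methylamino on a saturated chain carbon bound to a carbonyl carbon. Among the measured compounds shown here, no pair of measured compounds shows this change on its own, so no step size for it is known from the data. The expectation in this assay is a step not beyond the scatter, in no set direction. Compound 4 is estimated at 9000 nM, with a range from 3500 nM to 25000 nM. The step this estimate means is a 1.4-fold lower number from compound 3 to compound 4 (0.15 log units; within the scatter).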

Compound 4, half-maximal inhibitory concentration: 46100 nM
The estimate for compound 4 lay 5.1-fold (0.71 log units) below the measured number; the measured number lies above the stated range.
By their numbers in this assay, from the lowest: compound 2; then compounds 1 and 3 (each within the scatter of the next); then compound 4.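

In this assay, among the compounds shown here, the only one-place comparison reads a 3.6-fold higher number from compound 3 to compound 4 (0.56 log units; beyond the scatter) and shows that the saturated chain carbon bound to a carbonyl carbon does not tolerate every amine equally. On this core, 4-methylpiperazin-1-yl gives a weaker inhibitor than methylamino. No measurement on hand accounts for this step.

As far as these compounds go, whether the step follows the ring itself remains open: dimethylamino, piperidin-1-yl or morpholin-4-yl at this place would test that. From the compounds shown here alone, whether the same change acts alike on the core of compound 1 also remains open.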